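Swapping cyclopentylamino for methoxy: expected cytotoxicity of compound 4

The source may report more compounds than this note shows. Statements on the series, on what has been measured and on what is new or still open speak of the compounds shown alone.

Among the compounds with values here, compound 1 `Fc1ccc(-c2nn3ccc(NC4CCCC4)cc3c2-c2ccnc(NC3CCCC3)n2)cc1` is the only member of this small set with a measured number in an ADME assay on Vero cells (Chlorocebus sabaeus) for cytotoxicity (on this read-out lower numbers stand for higher toxicity in this test and higher numbers for lower toxicity in this test), where compound 1 gives 18000 nM. Compound 2 `Fc1ccc(-c2nn3c(NC4CCCC4)cc(NC4CCCC4)cc3c2-c2ccnc(NC3CCCC3)n2)cc1` reaches only the limit of this assay, at > 40000 nM. Compound 3 `CC(C)Sc1cc(NC2CCCC2)cc2c(-c3ccnc(NC4CCCC4)n3)c(-c3ccc(F)cc3)nn12` likewise reaches only the limit, at > 40000 nM. From the compounds shown here alone, the step of an at least 2.2-fold higher number from compound 1 to compound 2 (0.34 log units; beyond the scatter) and the step of an at least 2.2-fold higher number from compound 1 to compound 3 (0.34 log units; beyond the scatter) both end at that limit (the limit of > 40000 nM in this assay, at which 2 of the 3 values shown sit), so their true size is unknown. Compound 4 `COc1ccn2nc(-c3ccc(F)cc3)c(-c3ccnc(NC4CCCC4)n3)c2c1` differs from compound 1 by methoxy in place of cyclopentylamino on an aromatic carbon. Within the data shown here, none of the measured steps swaps a group at this carbon, so no direction is expected beyond the scatter. Compound 4 is therefore estimated at 20000 nM, from 7000 nM to 50000 nM, a step of a 1.1-fold higher number from compound 1 to compound 4 (0.05 log units; within the scatter) expected from compound 1 to compound 4.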

Compound 4, half-maximal cytotoxic concentration: > 36000 nM
Compound 4 ended at the assay's limit (the forecaster's own chance of this, stated with the estimate: 35%); middle value at least 1.8-fold (0.25 log units) from the limit.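

Compound 4 gives > 36000 nM in this assay, which is a limit and not a number. This is the first change shown at this aromatic carbon, and an at least 2.0-fold higher number from compound 1 to compound 4 (0.30 log units; that floor lies within the scatter) shows that trading cyclopentylamino for the much smaller methoxy does not lower the number. The true size of the step stays unknown, and its floor does not clear the usual scatter: the limit of > 36000 nM in this assay, at which 1 of the 4 values shown sits.

From the compounds shown here alone, it remains open whether the rise is real, and how far this carbon tolerates other groups. A carboxylic acid, a primary amine or a longer chain such as butoxy could read differently here.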